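A Bromine Added to a Rho Kinase Inhibitor

The compounds below may be only part of what the source reports. "The series", "measured", "known", "first", "only" and "open" are said of these compounds alone.

Of the compounds shown here, two have been measured so far in an assay on isolated protein for inhibition of Rho-associated protein kinase 2 (Homo sapiens), read by scintillation counting, radiometric assay and 33P incorporation, with a stated time of 40 min, in the presence of a further agent that is not named here; a higher number here means a weaker inhibitor, a lower number a stronger inhibitor. Compound 1, `CN(C)c1ccc(C(=O)Nc2cccc(NC(=O)COc3ccc4c(c3)NC(=O)CC4)c2)cc1`, gives 3140 nM in this assay. Compound 2, `O=C(COc1ccc2c(=O)ccoc2c1)Nc1cccc(NC(=O)c2ccccc2)c1`, gives 16 nM in this assay, which is the lowest of the two numbers; the gap to compound 1 lies beyond the usual scatter. Within the data shown here, no pair of measured compounds differs in only one place, so no single structural change has yet been tied to a shift in the numbers.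

Compound 3, `O=C(COc1ccc2c(=O)ccoc2c1)Nc1cccc(NC(=O)c2ccc(Br)cc2)c1`, is the next compound to be measured. It differs from compound 2 by one change: bromo in place of hydrogen on an aromatic carbon. Put simply, bromo replaces hydrogen on an aromatic carbon of a six-membered aromatic ring of carbon only, so the benzoyl group of compound 2 becomes a (4-bromophenyl)carbonyl group in compound 3.

Among the measured compounds shown here, with no measured step to lean on, the expectation is that the step of a 1.3-fold higher number from compound 2 to compound 3 (0.10 log units; within the scatter) will be small, most likely within the scatter in either direction. Compound 3 is therefore expected to give about 20 nM in this assay, with a likely range from 6 nM to 70 nM.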

Compound 3, half-maximal inhibitory concentration: 49 nM
The estimate for compound 3 lay 2.5-fold (0.39 log units) below the measured number, and the stated range covers the measured number.
By their numbers in this assay, from the lowest: compound 2; then compound 3; then compound 1.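

In this assay, bromo in place of hydrogen on the aromatic carbon para to a large group brings a 3.1-fold higher number from compound 2 to compound 3 (0.49 log units; beyond the scatter) and so points to a weaker inhibitor. Among these compounds, this is the first single change whose effect can be read on its own, and it shows that this position is not indifferent to what sits there: one added bromine atom moves the number beyond the usual scatter, although the step is only modest. Nothing measured here explains the rise.

A single substituent cannot show whether the rise belongs to bromo in particular or would follow from any group at this position, so a fluoro, a methoxy, an amine or a carboxylic acid on the same carbon could land on either side of compound 2. Also open, going by these compounds, is whether bromo on another carbon of the same ring would behave alike, and whether this change would move the number the same way on the core of compound 1.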